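Aromatic Esters Replacing Acetate: Rat Plasma Stability Outlook

This account rests on a few compounds, and the source may have more. Where it says the series, first, only, none or still open, it means among the compounds named here.

The measured compounds and their numbers:
compound 1, `CC(=O)Oc1ccccc1C(=O)O[C@H]1CO[C@H]2[C@@H]1OC[C@H]2OC(=O)c1ccnn1C`, 0.0963 h;
compound 2, `CC(=O)Oc1ccccc1C(=O)O[C@H]1CO[C@H]2[C@@H]1OC[C@H]2OC(C)=O`, 0.0608 h;
compound 3, `CC(=O)Oc1ccccc1C(=O)O[C@H]1CO[C@H]2[C@@H]1OC[C@H]2OC(=O)c1cnoc1C`, 0.193 h.

All three were run in an ADME assay on a cell-free system (plasma, Homo sapiens) for metabolic stability, with Plasma (Rattus norvegicus) as the target, read by HPLC, at pH 7.4; on this read-out lower numbers stand for a shorter-lived compound and higher numbers for a longer-lived compound. Compound 2 holds the lowest of the three numbers; compound 1 sits nearest to it, and compound 3 is the furthest away. Compound 4, `CC(=O)Oc1ccccc1C(=O)O[C@H]1CO[C@H]2[C@@H]1OC[C@H]2OC(=O)c1ccccc1CO[N+](=O)[O-]`, has not yet been measured. It differs from compound 2 in one place: 2-((nitrooxy)methyl)phenyl in place of methyl on a carbonyl carbon.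

Among the measured compounds shown here, two measured steps bear on this change, both leaving compound 2 by swapping its methyl on the same carbonyl carbon for a ring: a 3.2-fold higher number from compound 2 to compound 3 (0.50 log units; beyond the scatter), and, read through compound 1, the step of a 1.6-fold lower number from compound 1 to compound 2 (0.20 log units; within the scatter) shows that compound 1 also sits higher than compound 2. Both point the same way, so a modest rise in this assay is expected for a ring in place of methyl, and compound 4 is estimated at 0.15 h, within a range of 0.06 h to 0.4 h. That estimate means a step of a 2.5-fold higher number from compound 2 to compound 4 (0.39 log units; beyond the scatter), expected to be comparable in size to the measured ring-for-methyl steps rather than beyond them.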

Compound 4, half-life: 0.045 h
Compound 4: the middle estimate sits 3.3-fold (0.52 log units) above what was measured; the measured number lies below the stated range.
By their numbers in this assay, from the lowest: compounds 4, 2, 1 and 3 (each within the scatter of the next, the first and the last beyond it).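

In this assay, the 2-((nitrooxy)methyl)phenyl group on this carbonyl carbon gives a result that cannot be separated from that of methyl (a 1.4-fold lower number from compound 2 to compound 4 (0.13 log units; within the scatter)), so a ring at this position does not by itself set a compound apart from compound 2. The ring also matters by identity, as this entering group stands clearly apart from both other rings (a 4.3-fold lower number from compound 3 to compound 4 (0.63 log units; beyond the scatter); a 2.1-fold lower number from compound 1 to compound 4 (0.33 log units; beyond the scatter)). No measurement shown accounts for these differences.

The compounds shown leave open whether the result for compound 4 belongs to its phenyl ring or to the nitrooxymethyl group on that ring. An unsubstituted phenyl or a 2-(hydroxymethyl)phenyl on the same carbonyl carbon would help to separate those two parts.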